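Compound 2 to compound 3: notes on microsomal clearance

The source may report more compounds than this note shows. Statements on the series, on what has been measured and on what is new or still open speak of the compounds shown alone.

Among the compounds with values here, in an ADME assay on microsomes from liver (Rattus norvegicus) for metabolic stability, read by LC-MS, with a stated time of 4 h, tested at 1 uM (a higher number here means faster removal of the compound, a lower number slower removal), compound 2 (`Cc1c(Cc2ccc(C(F)(F)F)nc2)c[nH]c1C(=O)NC(C)c1cnn(C)c1`) gives 21000 mL.min-1.g-1 as the only actual number so far. Compound 1 (`Cc1cc(Nc2ccc(S(F)(F)(F)(F)F)cc2)n2nc(C(F)(F)F)nc2n1`) gives only a limit of < 7000 mL.min-1.g-1 and no number.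

Compound 3 (`Cc1cc(C(C)NC(=O)c2[nH]cc(Cc3ccc(C(F)(F)F)nc3)c2C)no1`) is still unmeasured and differs from compound 2 by 5-methyl-1,2-oxazol-3-yl in place of 1-methyl-1H-pyrazol-4-yl on a saturated chain carbon bound to an amide-type nitrogen and a saturated chain carbon with 5-methyl-1,2-oxazol-3-yl in place of 1-methyl-1H-pyrazol-4-yl on a saturated chain carbon bound to an amide-type nitrogen and a saturated chain carbon.

Within the data shown here, no measured pair tests this exchange, so only a small move towards faster removal is expected. The expected step of a 1.3-fold higher number from compound 2 to compound 3 (0.12 log units; within the scatter) stays within the usual scatter of this assay and leans on compound 2 alone.

In this assay the expected value for compound 3 is 28000 mL.min-1.g-1 within an estimated range of 11000 mL.min-1.g-1 to 60000 mL.min-1.g-1 for now.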

Compound 3, intrinsic clearance in microsomes in the Rattus norvegicus assay: 29000 mL.min-1.g-1
Compound 3: the middle estimate sits 1.0-fold (0.02 log units) below what was measured; measured number inside the range.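

In the Rattus norvegicus assay, 5-methyl-1,2-oxazol-3-yl in place of 1-methyl-1H-pyrazol-4-yl on a saturated chain carbon bound to an amide-type nitrogen and a saturated chain carbon gives a 1.4-fold higher number from compound 2 to compound 3 (0.14 log units; within the scatter), so this read-out does not separate the two rings. In a physicochemical assay for solubility, in simulated intestinal fluid, with a stated time of 5 h, at pH 5.8 (on this read-out lower numbers stand for lower solubility and higher numbers for higher solubility), compound 2 gives 158 ug/mL and compound 3 gives 47.8 ug/mL. In the physicochemical assay, the same exchange comes with a real loss of solubility: the measured solubility of compound 2, 158 ug/mL, and of compound 3, 47.8 ug/mL, a 3.3-fold lower number (0.52 log units; beyond the scatter). For this one pair, then, solubility is the only read-out that tells the two groups apart.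

As far as these compounds go, whether a group of another kind at this place, such as an amine or a carboxylic acid, would separate the compounds in the Rattus norvegicus assay stays open. Also open, from the compounds shown here alone, is whether the exchange would give the same two results with a nitrile in place of the trifluoromethyl group.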